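The source may report more compounds than this note shows. Statements on the series, on what has been measured and on what is new or still open speak of the compounds shown alone.

Measured compounds in a functional assay on HepG2 cells (Homo sapiens) for antiproliferative activity, read by MTT assay, with a stated time of 48 h; a lower number here means a stronger inhibitor, a higher number a weaker inhibitor: compound 1 `O=c1cc(-c2ccccc2)oc2cc(OCc3ccccc3)c(OCCCN3CCCC3)c(O)c12` gives 4200 nM; compound 2 `O=c1cc(-c2ccccc2)oc2cc(OCc3ccccc3)c(OCCCCN3CCCCC3)c(O)c12` gives 2400 nM; compound 3 `CN1CCN(CCCCOc2c(OCc3ccccc3)cc3oc(-c4ccccc4)cc(=O)c3c2O)CC1` gives 2500 nM.

Compound 3 sits second highest of the three numbers, close to compound 2 and within the scatter of compound 1. For the measured compounds named here, the steps so far, a 1.8-fold lower number from compound 1 to compound 2 (0.24 log units; within the scatter) and a 1.7-fold lower number from compound 1 to compound 3 (0.23 log units; within the scatter) and a 1.0-fold higher number from compound 2 to compound 3 (0.02 log units; within the scatter), all concern the amine at the chain end and all lie within the scatter.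

Compound 4 `COc1cc2oc(-c3ccccc3)cc(=O)c2c(O)c1OCCCCN1CCN(C)CC1` differs from compound 3 by hydrogen in place of phenyl on a saturated chain carbon bound to an oxygen on an aromatic ring. Going by the values given here, no measured step touches this part of the molecule, so the data give no basis for a direction. The expectation for compound 4 in this assay is therefore a number near compound 3, no change at the digits printed from compound 3 to compound 4 (within the scatter), with a wide range: estimated 2500 nM, between 800 nM and 8000 nM.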

Compound 4, half-maximal inhibitory concentration: 36700 nM
Beside the measured number, compound 4's estimate is 15-fold (1.17 log units) below it, outside the stated range (above it).
By their numbers in this assay, from the lowest: compounds 2, 3 and 1 (each within the scatter of the next); then compound 4.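

In this assay, for the compounds shown here, benzyloxy to methoxy gives a 15-fold higher number from compound 3 to compound 4 (1.17 log units; beyond the scatter), the first step beyond the scatter; the amine changes at the chain end all stayed within it. Among the compounds shown, the phenyl at this place therefore counts for more than any amine swap, though a single pair carries that reading. No evidence bears on what lies behind this step.

As far as these compounds go, it remains open whether a cyclohexylmethyl or a 2-phenylethyl on this oxygen would keep the number near that of compound 3. From the compounds shown here alone, whether a pyrrolidine or piperidine at the chain end would matter more in the methoxy series is also open.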